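Pyridinyl in place of the bicyclic aryl on compound 2

A few compounds are considered here, and "the series" means these few. Any claim that something is new, unique, unknown or untested is made for them only; others in the source may bear on it.

Working notes on the series. Three compounds are known in a functional assay on HCT-116 cells (Homo sapiens) for inhibition, read by MTT assay, with a stated time of 72 h; a lower number here means a stronger inhibitor of growth, a higher number a weaker inhibitor of growth. Compound 1 `COC1=C(C)C(=O)C(CCCCCCCCCCn2cc(C[C@H](O)COCCOC[C@@H](O)Cc3ccc(-c4ccccc4)cc3)nn2)=C(C)C1=O` gives 4000 nM, compound 3 `COC1=C(OC)C(=O)C(CCCCCCCCCCCCCCCn2cc(C[C@H](O)COCCOC[C@@H](O)Cc3ccc(-c4ccccc4)cc3)nn2)=C(C)C1=O` gives 1500 nM, and compound 2 `O=C1COc2ccc(-n3cc(C[C@H](O)COCCOC[C@@H](O)Cc4ccc(-c5ccccc5)cc4)nn3)cc2N1` gives 42500 nM, the highest number of the three, beyond the scatter from both others, so compound 2 is the weakest growth inhibitor shown. Compound 4 `O[C@H](COCCOC[C@@H](O)Cc1cn(-c2cccnc2)nn1)Cc1ccc(-c2ccccc2)cc1` keeps the shared core of compound 2 and differs only on an aromatic nitrogen: a group of 6 heavy atoms (5 carbon, 1 nitrogen; one six-membered aromatic ring with 1 hetero atom) in place of a group of 11 heavy atoms (8 carbon, 1 nitrogen, 2 oxygen; one six-membered non-aromatic ring with 2 hetero atoms, one six-membered aromatic ring of carbon only), on an aromatic nitrogen. For the measured compounds named here, no step between measured compounds that differ in one place is available. Compound 2 carries an aromatic group where compound 1 and compound 3 carry a chain, and compound 4 likewise carries an aromatic group there, so the expected step of a 1.4-fold higher number from compound 2 to compound 4 (0.15 log units; within the scatter) is small or toward a higher number. The estimated value for compound 4 is 60000 nM, with a range of 20000 nM to 180000 nM.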

Compound 4, concentration for 50% growth inhibition: 46800 nM
The estimate for compound 4 lay 1.3-fold (0.11 log units) above the measured number, and the stated range covers the measured number.
By their numbers in this assay, from the lowest: compound 3; then compound 1; then compounds 2 and 4 (each within the scatter of the next).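

In this assay, pyridin-3-yl in place of the larger two-ring group on the aromatic nitrogen gives a 1.1-fold higher number from compound 2 to compound 4 (0.04 log units; within the scatter), so removing the non-aromatic ring and the hydrogen-bond donor brings no readable change at this position. For the compounds shown here, this is the first one-place comparison, and it shows that this smaller aromatic group and the two-ring group cannot be told apart here. No accompanying measurement offers an explanation for this result.

On these data alone, whether pyridin-2-yl, pyridin-4-yl, or an amine or carboxylic acid on the pyridine ring would move the number remains open. The compounds shown also cannot isolate the effect of a long alkyl chain on this nitrogen, since compound 1 and compound 3 differ from compound 4 in more than one place.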